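The source may hold more compounds than are shown below. What is called first, only, known or untested is meant among the compounds shown, and "the series" means these compounds.

Of the compounds shown here, three with a shared core have been tested in a functional assay on A549 cells (Homo sapiens) for inhibition, read by sulforhodamine B assay, tested at 100 uM; on this read-out higher numbers stand for more inhibition of growth at the one concentration tested and lower numbers for less inhibition of growth. Compound 1 `CC(=O)N1N=C(c2ccc(OCc3cn(Cc4ccc([N+](=O)[O-])cc4)nn3)cc2)CC1c1ccccc1` gives 80%. Going by the values given here, compound 2 `COc1ccc(C2CC(c3ccc(OCc4cn(Cc5ccc([N+](=O)[O-])cc5)nn4)cc3)=NN2C(C)=O)cc1` gives 33%, and the change a number 47 percentage points lower from compound 1 to compound 2 (beyond the scatter) is the only single-point step measured so far. Compound 3 `COc1cc(C2CC(c3ccc(Br)cc3)=NN2C(C)=O)ccc1OCc1cn(Cc2ccc([N+](=O)[O-])cc2)nn1` gives 17%; this is the lowest of the three numbers, with compound 2 standing nearest to it and compound 1 furthest, and both of those gaps lie beyond the scatter.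

Compound 4 `COc1cc(C2CC(c3ccc(Cl)cc3)=NN2C(C)=O)ccc1OCc1cn(Cc2ccc([N+](=O)[O-])cc2)nn1` differs from compound 3 in one place: chloro in place of bromo on an aromatic carbon. Among the compounds with values here, no measured step concerns this kind of exchange. Within the data shown here, the one step that has been measured, a number 47 percentage points lower from compound 1 to compound 2 (beyond the scatter), concerns a different group at a different place on the core, so it says nothing about swapping one halogen for another on the aromatic carbon para to the large group. Among the measured compounds shown here, with no measured step to draw on, the step from compound 3 to compound 4, a number 1 percentage points higher from compound 3 to compound 4 (within the scatter), is expected to stay within the scatter, in no particular direction. Compound 4 is therefore estimated to give 18% in this assay, with a range from 5% to 35%.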

Compound 4, percent growth inhibition at one concentration: 0%
Estimate against measurement, compound 4: 18 percentage points above; measured number outside the range, below it.
By their numbers in this assay, from the lowest: compound 4; then compound 3; then compound 2; then compound 1.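

The step from 4-bromophenyl to 4-chlorophenyl is a number 17 percentage points lower from compound 3 to compound 4 (beyond the scatter) in this assay, so this place on the shared core is not indifferent to which halogen it carries. The exchange touches a single heavy atom, with no ring, no hydrogen-bond donor or acceptor and no net charge on either side, and yet it moves the number beyond the scatter. Going by these compounds alone, none of the earlier steps concerned this place. With bromo, compound 3 gives 17%, whereas with chloro compound 4 gives 0%, and nothing available here explains why these two halogens differ in this way.

Within the data shown here, what remains open is whether this halogen step would read the same on another version of the shared core, as the only example stands on the core of compound 3. Going by these compounds, it is equally open how fluoro, iodo, a methyl group, an amine or a carboxylic acid on the same aromatic carbon would read in this assay and whether any of them would stand with bromo or with chloro.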